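Fluorine on the Benzyl Group of Compound 2

A few compounds are considered here, and "the series" means these few. Any claim that something is new, unique, unknown or untested is made for them only; others in the source may bear on it.

Measured in a functional assay on Bel-7402 cells (Homo sapiens) for antiproliferative activity, read by MTT assay, with a stated time of 72 h; a higher number here means a weaker inhibitor, a lower number a stronger inhibitor:
compound 1 `COc1cccc(CNCc2c(C(=O)O)n(Cc3ccccc3)c3cc(C(C)C)ccc23)c1` gives 5900 nM.
compound 2 `COc1cccc(CNCc2c(C(=O)O)n(Cc3ccccc3)c3ccccc23)c1` gives only the assay limit > 50000 nM.
compound 3 `COc1ccc(Cn2c(C(=O)O)c(CNCc3cc(OC)ccc3O)c3ccc(C)cc32)cc1` gives only the assay limit > 50000 nM.

Compound 2 thus sits at the limit, where two of the three values shown rest (the limit of > 50000 nM in this assay, at which 2 of the 3 values shown sit). Compound 4 `COc1cccc(CNCc2c(C(=O)O)n(Cc3ccc(F)cc3)c3ccccc23)c1` differs from it by fluoro in place of hydrogen on an aromatic carbon. Among the compounds with values here, the single measured step, an at least 8.4-fold higher number from compound 1 to compound 2 (0.92 log units; beyond the scatter), exchanges a group on a different ring, so it does not bear on adding fluoro to the benzyl group, and no measured pair involves fluoro at all. Since compound 2 already rests at the limit, compound 4 is expected to stay close to it, with a step that the limit leaves unreadable from compound 2 to compound 4 not clearly beyond the scatter. Compound 4 is estimated at 60000 nM, between 20000 nM and 200000 nM, and will most likely again be reported only as a limit.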

Compound 4, half-maximal inhibitory concentration: > 50000 nM
Compound 4: a limit, no number; the forecaster's own chance of this, stated with the estimate: 70%; the middle value is on the limit's open side.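

Compound 2 and compound 4 both rest at the assay limit, so no step can be read between them: the limit of > 50000 nM in this assay, at which 3 of the 4 values shown sit.

The compounds shown leave open whether 4-fluorobenzyl in place of benzyl changes the activity at all.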